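Moving a Methoxy Group: Half-Life Expected to Stay Long

A few compounds are considered here, and "the series" means these few. Any claim that something is new, unique, unknown or untested is made for them only; others in the source may bear on it.

Measured compounds:
Compound 1, `O=C(NCc1cccc2ccccc12)N1C(=O)c2ccccc2S1(=O)=O`. In a physicochemical assay for pharmacokinetics (a higher number here means that the compound lasts longer, a lower number that the compound disappears faster), compound 1 gives > 166 h. That value is a limit of the assay, not a number.
Compound 2, `COc1cccc(CNC(=O)N2C(=O)c3ccccc3S2(=O)=O)c1`. In this assay compound 2 gives > 166 h. That value is also a limit.
Compound 3, `O=C(c1ccccc1)N1Cc2ccccc2C1=O`. In this assay compound 3 gives > 166 h. That value is again a limit.

Compound 2 therefore stands only at a limit, and the two other values shown sit at the same limit, so no one of the three can be ranked against the others; this is the limit of > 166 h in this assay, at which 3 of the 3 values shown sit. Among the compounds with values here, no pair of measured compounds differs in one place, so no measured step exists.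

The compound not yet measured is compound 4, `COc1ccccc1CNC(=O)N1C(=O)c2ccccc2S1(=O)=O`. Its difference from compound 2 is 2-methoxyphenyl in place of 3-methoxyphenyl on a saturated chain carbon bound to an amide-type nitrogen. The atoms are the same and only their joining differs.

With nothing but three limit values to go on, the step from compound 2 to compound 4 in this assay is expected to be none beyond the usual scatter, and compound 4 is expected to reach the limit again. Compound 4 is estimated at 200 h, with a range from 80 h to 500 h, so that the expected step is a step that the limit leaves unreadable from compound 2 to compound 4.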

Compound 4, half-life: > 166 h
Compound 4 gave a limit, no number; the forecaster's own chance of this, stated with the estimate: 80%; the middle value lies beyond the limit too.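

In this assay compound 2 and compound 4 each give a limit rather than a number, so no step between them can be read: the limit of > 166 h in this assay, at which 4 of the 4 values shown sit.

The compounds shown leave open how long any of them really lasts, and whether 2-methoxyphenyl in place of 3-methoxyphenyl changes the half-life at all.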